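A few compounds are considered here, and "the series" means these few. Any claim that something is new, unique, unknown or untested is made for them only; others in the source may bear on it.

Measured in a functional assay on C6 cells (Rattus norvegicus) for inhibition, read by sulforhodamine B assay, with a stated time of 72 h; on this read-out higher numbers stand for an effect only at larger amounts of compound and lower numbers for an effect already at smaller amounts:
Compound 1 `CC(C)(C)c1ccc(C(=O)/C=C/c2ccc([N+](=O)[O-])o2)cc1`: 28600 nM
Compound 2 `Cc1cccc(C(=O)/C=C/c2ccc([N+](=O)[O-])o2)c1`: 2100 nM

Of these two, compound 2 holds the lower number, and compound 1 lies above it by more than the scatter. The next compound, compound 3 `O=C(/C=C/c1ccc([N+](=O)[O-])o1)c1cccc(Br)c1`, has not yet been measured. It has bromo in place of methyl on an aromatic carbon, on a six-membered aromatic ring of carbon only, meta to a large group: bromo in place of methyl on an aromatic carbon. For the measured compounds named here, no measured pair shows this exchange, so the expectation starts from compound 2 at 2100 nM. A step beyond the scatter in this assay is not expected in either direction. The estimate amounts to an expected 1.1-fold lower number from compound 2 to compound 3 (0.02 log units; within the scatter). For compound 3 the estimated value is 2000 nM, with an expected range from 700 nM to 6000 nM.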

Compound 3, half-maximal effective concentration: 1400 nM
The estimate for compound 3 lay 1.4-fold (0.15 log units) above the measured number; the measured number falls inside the stated range.
By their numbers in this assay, from the lowest: compounds 3 and 2 (each within the scatter of the next); then compound 1.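

In this assay the exchange of methyl for bromo on an aromatic carbon, meta to a large group, comes to a 1.5-fold lower number from compound 2 to compound 3 (0.18 log units; within the scatter) and so leaves the read-out without a real difference between the two groups at this position. For the compounds shown here, this is the first step that can be read as a single change, as compound 1 and compound 2 differ in more than one place. Nothing measured here accounts for the two groups reading alike.

The compounds shown leave open whether this position tolerates groups of another kind, such as an amine, a carboxylic acid or a methoxy group, or whether only methyl and bromo read alike. They also leave open whether the same exchange would give so small a step elsewhere on the shared core.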